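Removing the ring chlorine from a thiadiazole acetamide

A few compounds are considered here, and "the series" means these few. Any claim that something is new, unique, unknown or untested is made for them only; others in the source may bear on it.

The series shares one core, a pyridyl-substituted thiadiazole joined through a sulfur-linked acetamide to a benzylic or anilide nitrogen. Compound 1 `CC(Sc1nnc(-c2ccncc2)s1)C(=O)NCc1ccccc1Cl` carries a methyl on the linker carbon and a 2-chlorobenzyl amide. In an ADME assay on BHK-21 cells (Mesocricetus auratus) for cytotoxicity, with a stated time of 3 days (a higher number here means that more compound is tolerated, a lower number that less compound is tolerated), compound 1 reaches only a limit of the assay, > 50000 nM. Compound 2 `CC(Sc1nnc(-c2ccncc2)s1)C(=O)Nc1ccc(Cl)cc1` also stops at a limit, giving > 50000 nM in this assay. The step that the two limits leave unreadable from compound 1 to compound 2 therefore cannot be read, as the two limits hide it. Compound 3 `O=C(CSc1nnc(-c2ccncc2)s1)NCc1ccccc1Cl` lacks the linker methyl and has no reported result, its entry in this assay being "not determined" (no result reported); it stands among values of which two sit at the limit of > 50000 nM in this assay, at which 2 of the 3 values shown sit.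

Compound 4 `O=C(CSc1nnc(-c2ccncc2)s1)NCc1ccccc1` differs from compound 3 by the change (hydrogen in place of chloro on an aromatic carbon), the chloro leaving an aromatic carbon of a six-membered aromatic ring of carbon only. Going by the values given here, no measured step bears directly on this change; the only measured pair is unreadable. Compound 4 is therefore expected to be tolerated up to about 60000 nM in this assay, with a range from 30000 nM to 150000 nM, most likely reported again as a limit.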

Compound 4, half-maximal cytotoxic concentration: 11300 nM
For compound 4 the middle estimate is 5.3-fold (0.73 log units) above the measured one, outside the stated range (below it).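

No new step can be read from compound 4, at 11300 nM, since compound 3 offers no number to set against it. The compounds shown leave open what hydrogen in place of chloro does in this assay, where the other values are limits: the limit of > 50000 nM in this assay, at which 2 of the 4 values shown sit.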